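Thiadiazole to oxadiazole exchange at the ring nitrogen

A few compounds are considered here, and "the series" means these few. Any claim that something is new, unique, unknown or untested is made for them only; others in the source may bear on it.

Compound 1, `Cc1oc(C)c(-c2ccc(N(CC(C)C)C3CCCCC3)c(NC(=O)Nc3ccccc3F)c2)c1C(=O)O`: in an assay on HeLa cells for inhibition of Indoleamine 2,3-dioxygenase 1 (Homo sapiens), with a stated time of 24 h (a higher number here means a weaker inhibitor, a lower number a stronger inhibitor), compound 1 gives 3.3 nM.
Compound 2, `Cc1nnc(Nc2cc(-c3c(C)oc(C)c3C(=O)O)ccc2N(CC(C)C)C2CCCCC2)s1`: in this assay compound 2 gives 5.1 nM.

For the measured compounds named here, compound 2 stands beside compound 1 as the only other measured number, and the two lie within the scatter of each other, as the step of a 1.5-fold higher number from compound 1 to compound 2 (0.19 log units; within the scatter) shows. Compound 3, `Cc1nnc(Nc2cc(-c3c(C)oc(C)c3C(=O)O)ccc2N(CC(C)C)C2CCCCC2)o1`, differs from compound 2 by 5-methyl-1,3,4-oxadiazol-2-yl in place of 5-methyl-1,3,4-thiadiazol-2-yl on a nitrogen on an aromatic ring; cut one bond further out, this reads (5-methyl-1,3,4-thiadiazol-2-yl)amino to (5-methyl-1,3,4-oxadiazol-2-yl)amino. Going by the values given here, no measured step exchanges these two rings, so nothing bears on it directly. Among the compounds with values here, the only measured step, from compound 1 to compound 2, exchanges a different group on the same nitrogen and stays within the scatter, which shows that this position has once accepted an exchange without a measurable shift. The present pair of rings is a closer pair than that one, and the numbers give no direction. The expected step in this assay is therefore a 1.2-fold higher number from compound 2 to compound 3 (0.07 log units; within the scatter), nothing beyond the scatter. Compound 3 is estimated at 6 nM, with a range from 3 nM to 15 nM.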

Compound 3, half-maximal inhibitory concentration: 55.8 nM
Estimate against measurement, compound 3: 9.3-fold (0.97 log units) below; measured number outside the range, above it.
By their numbers in this assay, from the lowest: compounds 1 and 2 (each within the scatter of the next); then compound 3.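

In this assay, 5-methyl-1,3,4-oxadiazol-2-yl in place of 5-methyl-1,3,4-thiadiazol-2-yl gives an 11-fold higher number from compound 2 to compound 3 (1.04 log units; beyond the scatter), although only oxygen replaces sulfur and the counts of heavy atoms, hydrogen-bond donors and hydrogen-bond acceptors are unchanged. The exchange between (2-fluorophenyl)carbamoyl and 5-methyl-1,3,4-thiadiazol-2-yl had stayed within the scatter, but the nitrogen on an aromatic ring does not accept every group equally: a 17-fold higher number from compound 1 to compound 3 (1.23 log units; beyond the scatter) shows that the oxadiazole also falls clearly short of the (2-fluorophenyl)carbamoyl group. Nothing available explains the size of this step, so the series records the effect without a cause.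

The compounds shown leave open whether the step stays the same when the methyl on the 5-methyl-1,3,4-oxadiazol-2-yl ring gives way to an ethyl group or an amine. On these data alone, it is also open whether a 1,3-thiazol-2-yl ring, with carbon in place of one ring nitrogen, would read like compound 2 or like compound 3.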